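Compound 2: ethoxy replaced by ((trifluoromethyl)sulfonyl)amino

The source may report more compounds than this note shows. Statements on the series, on what has been measured and on what is new or still open speak of the compounds shown alone.

In a functional assay for inhibition, with Homo sapiens as the target (on this read-out higher numbers stand for weaker inhibition and lower numbers for stronger inhibition), three compounds have been measured so far: compound 1 (`COc1cc(OC)c(C(=O)/C=C/c2ccc([N+](=O)[O-])cc2)c(OC)c1`) gives 407 nM, compound 2 (`CCOc1ccccc1C(=O)/C=C/c1ccccc1`) gives 609 nM and compound 3 (`O=C(/C=C/c1ccccc1)c1c(Cl)cccc1Cl`) gives 1080 nM. Compound 2 stands second highest of the three numbers, within the scatter of both others. Compound 4 (`O=C(/C=C/c1ccccc1)c1ccccc1NS(=O)(=O)C(F)(F)F`) carries ((trifluoromethyl)sulfonyl)amino in place of ethoxy on an aromatic carbon. Among the compounds with values here, no measured pair differs in only one place, so the series gives no direct guide to this change, and the expectation rests on the narrow spread of the three values. The expected step, a 1.3-fold higher number from compound 2 to compound 4 (0.12 log units; within the scatter), is small, toward a higher number and not beyond the scatter. For compound 4 the estimated value in this assay is 800 nM, with an expected range of 250 nM to 2800 nM.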

Compound 4, half-maximal inhibitory concentration: 5850 nM
For compound 4 the middle estimate is 7.3-fold (0.86 log units) below the measured one, outside the stated range (above it).
By their numbers in this assay, from the lowest: compounds 1, 2 and 3 (each within the scatter of the next, the first and the last beyond it); then compound 4.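

In this assay the change from ethoxy to ((trifluoromethyl)sulfonyl)amino on an aromatic carbon gives a 9.6-fold higher number from compound 2 to compound 4 (0.98 log units; beyond the scatter) and so weaker inhibition, beyond the scatter. Within the data shown here, this is the first single-place step. It shows that this place, ortho to a large group, responds to the group it carries, which the three earlier values could not show.

Still open, as far as these compounds go, is whether the loss goes with the trifluoromethyl or with the sulfonylamino part, which a plain amine or a methylsulfonylamino group at the same place would separate. Nothing available explains the loss.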